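Alkoxy variation on a trimethoxyphenyl triazolopyridine series

The source may hold more compounds than are shown below. What is called first, only, known or untested is meant among the compounds shown, and "the series" means these compounds.

Measured so far:
compound 1 `CCOc1cc(-c2ccc3cc[nH]c3c2)cn2c(-c3cc(OC)c(OC)c(OC)c3)nnc12` — 626 nM
compound 2 `COc1cc(-c2nnc3c(OC)cc(-c4ccc5[nH]ccc5c4)cn23)cc(OC)c1OC` — 167 nM

In a functional assay on A549 cells (Homo sapiens) for antiproliferative activity, read by MTT assay, with a stated time of 48 h (a lower number here means a stronger inhibitor, a higher number a weaker inhibitor), compound 2 gives 167 nM, the lowest of the two numbers; compound 1 gives 626 nM, a gap beyond the scatter. Compound 3 `COc1cc(-c2nnc3c(OCC(F)(F)F)cc(-c4ccc5[nH]ccc5c4)cn23)cc(OC)c1OC` has not been measured. It differs from compound 2 by trifluoromethyl in place of hydrogen on a saturated chain carbon bound to an oxygen on an aromatic ring. For the measured compounds named here, no measured pair isolates this change, so its size is unknown. For compound 3 a moderate rise in number is expected, as a step of a 2.4-fold higher number from compound 2 to compound 3 (0.38 log units; beyond the scatter) in this assay, though a result within the scatter cannot be excluded. The estimate for compound 3 is 400 nM, with a range of 120 nM to 1300 nM.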

Compound 3, half-maximal inhibitory concentration: 585 nM
Estimate against measurement, compound 3: 1.5-fold (0.17 log units) below; measured number inside the range.
By their numbers in this assay, from the lowest: compound 2; then compounds 3 and 1 (each within the scatter of the next).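

In this assay, for the compounds shown here, methoxy to 2,2,2-trifluoroethoxy gives a 3.5-fold higher number from compound 2 to compound 3 (0.54 log units; beyond the scatter), the first change at this position read in a pair differing in one place. Compound 1 differs from compound 2 in more than one place, so it could not isolate this position; the pair now shows that the position responds to this change. No evidence on hand bears on the origin of this step. Open, going by these compounds, is whether a plain ethoxy group on the core of compound 2 would give a similar step, separating the fluorine atoms from the added carbon. Also open, on these data alone, is how a longer chain or a terminal amine would read here.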